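The compounds below may be only part of what the source reports. "The series", "measured", "known", "first", "only" and "open" are said of these compounds alone.

Working notes on the series, as read in an ADME assay on Vero 76 cells (Chlorocebus sabaeus) for cytotoxicity, read by microscopy; on this read-out higher numbers stand for lower toxicity in this test and lower numbers for higher toxicity in this test. Among the compounds with values here, compound 1 (`CC(C)[C@@H](Nc1nc(Cl)nc2c1ncn2[C@H]1[C@H](O)[C@H](O)[C@]2(CCl)C[C@H]12)C1CC1`) gives 32000 nM, the only value here that is a true number. Compound 2 (`CC[C@@H](Nc1nc(SC)nc2c1ccn2[C@H]1[C@H](O)[C@H](O)[C@]2(CO)C[C@H]12)C1CC1`) reads > 50000 nM, which is a limit of the assay and not a number. Compound 3 (`OC[C@@]12C[C@@H]1[C@@H](n1cnc3c(NCc4ccccc4)nc(Cl)nc31)[C@H](O)[C@@H]2O`) reads > 100000 nM, which is also a limit. Within the data shown here, compound 2 therefore stands on a limit alone, and compound 3 is the one other compound reported that way.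

Compound 4 (`CSc1nc(N[C@@H](C2CC2)C(C)(C)O)c2ccn([C@H]3[C@H](O)[C@H](O)[C@]4(CO)C[C@H]34)c2n1`) is compound 2 with one change: 1-hydroxy-1-methylethyl in place of ethyl on a saturated chain carbon bound to a nitrogen on an aromatic ring and a saturated ring carbon. The 1-hydroxy-1-methylethyl takes the place of ethyl on a saturated chain carbon bound to a nitrogen on an aromatic ring and a saturated ring carbon. Among the measured compounds shown here, no pair of measured compounds shows this change or any other single change, so this assay offers no direct measure of its size. No step beyond the usual scatter is expected, and no direction is assigned. The expected change is a step that the limit leaves unreadable from compound 2 to compound 4, an estimate that stays within that scatter. This expectation rests on compound 2, whose reading of > 50000 nM is a limit. A limit is also the most likely kind of report for the next reading. The estimated value for compound 4 is 60000 nM, with an expected range of 30000 nM to 100000 nM.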

Compound 4, half-maximal cytotoxic concentration: > 100000 nM
Compound 4 ended at the assay's limit; the forecaster's own chance of this, stated with the estimate: 75%; middle value at least 1.6-fold (0.22 log units) from the limit.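

Compound 2 and compound 4 both read as limits of the assay in this assay, and no step can be read between them. Whether 1-hydroxy-1-methylethyl in place of ethyl changes the half-maximal cytotoxic concentration at all, and in which direction, stays open: the compounds shown hold no pair across this change with true numbers on both sides.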